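The source may report more compounds than this note shows. Statements on the series, on what has been measured and on what is new or still open speak of the compounds shown alone.

Three compounds sharing one core carry different groups at a single aromatic carbon of that core. Compound 1, `O=C(Nc1ccc(-n2ncc3c(C(F)(F)F)cccc32)cc1)Nc1ccc(Cl)c(C(F)(F)F)c1`, gives 2900 nM in a functional assay on HT-29 cells (Homo sapiens) for cytotoxicity, read by MTT assay, with a stated time of 72 h; on this read-out higher numbers stand for weaker inhibition and lower numbers for stronger inhibition. Compound 2, `O=C(Nc1ccc(-n2ncc3c(Br)cccc32)cc1)Nc1ccc(Cl)c(C(F)(F)F)c1`, gives 4000 nM in this assay. Compound 3, `O=C(Nc1ccc(-n2ncc3ccccc32)cc1)Nc1ccc(Cl)c(C(F)(F)F)c1`, gives 18200 nM in this assay and thus stands highest of the three numbers, with compound 2 nearest and compound 1 furthest from it.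

Compound 4, `CNc1cccc2c1cnn2-c1ccc(NC(=O)Nc2ccc(Cl)c(C(F)(F)F)c2)cc1`, differs from compound 3 by a single change: methylamino in place of hydrogen on an aromatic carbon. Among the compounds with values here, two measured steps bear on this, both in the reverse sense of putting hydrogen in place of a group at the same kind of site. There was a 6.3-fold higher number from compound 1 to compound 3 (0.80 log units; beyond the scatter) and a 4.6-fold higher number from compound 2 to compound 3 (0.66 log units; beyond the scatter), so removing a group raised the number modestly in both cases, and by extension adding a group is expected to lower it. Methylamino is not trifluoromethyl or bromo, so the size of the effect for compound 4 rests on the direction alone. Compound 4 is therefore expected to show a 3.0-fold lower number from compound 3 to compound 4 (0.48 log units; beyond the scatter) in this assay. The estimated value of compound 4 in this assay is 6000 nM, with a range from 2500 nM to 16000 nM.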

Compound 4, half-maximal inhibitory concentration: 5900 nM
The estimate for compound 4 lay 1.0-fold (0.01 log units) above the measured number; the range from low to high includes it.
By their numbers in this assay, from the lowest: compounds 1, 2 and 4 (each within the scatter of the next, the first and the last beyond it); then compound 3.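

The earlier compounds shown here showed that trifluoromethyl and bromo at this aromatic carbon each gave a lower number than hydrogen, and methylamino, with its nitrogen and its hydrogen-bond donor, now does so as well in this assay with a 3.1-fold lower number from compound 3 to compound 4 (0.49 log units; beyond the scatter) and thus extends the finding to a third kind of group. Among these four compounds, hydrogen therefore gives the highest number at this position, and none of the three groups goes against that. The replacement of bromo by methylamino gives a 1.5-fold higher number from compound 2 to compound 4 (0.17 log units; within the scatter) and so cannot be told apart from no change, whereas the replacement of trifluoromethyl by methylamino gives a 2.0-fold higher number from compound 1 to compound 4 (0.31 log units; beyond the scatter) as a modest step that is printed as beyond the scatter.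

Nothing at hand bears on the reason for any of these steps.

As far as these compounds go, it remains open whether a longer chain such as ethylamino or dimethylamino, an unsubstituted amine, methoxy or a carboxylic acid at this carbon would also give a lower number than hydrogen, and whether any of them would go lower than compound 1 does.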